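A Benzylic Aryl Swap on a Shared Core

A few compounds are considered here, and "the series" means these few. Any claim that something is new, unique, unknown or untested is made for them only; others in the source may bear on it.

Compound 3 `Cc1ccccc1Cc1nc2cc(O[C@H]3CC[C@@H](C(=O)O)CC3)ccc2n1C` is tested in an assay on isolated protein for inhibition of Long-chain-fatty-acid--CoA ligase 1 (Mus musculus), read by mass spectrometry, with a stated time of 90 min, in the presence of a further agent that is not named here (on this read-out higher numbers stand for weaker inhibition and lower numbers for stronger inhibition), where it gives 5400 nM. Among the numbers that were actually measured, this is the highest of the two. Compound 1 `Cc1cccc(Cc2nc3cc(O[C@H]4CC[C@@H](C(=O)O)CC4)ccc3o2)c1` gives 140 nM in this assay, a gap from compound 3 that lies beyond the scatter. Compound 2 `Cc1cccc(Cc2nc3ccc(O[C@H]4CC[C@@H](C(=O)O)CC4)cc3n2C)c1` reaches only a limit of the assay, > 200000 nM, and no number; this is the limit of > 200000 nM in this assay, at which 1 of the 3 values shown sits.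

Compound 4 `Cn1c(Cc2cccc(C(F)(F)F)c2)nc2cc(O[C@H]3CC[C@@H](C(=O)O)CC3)ccc21` has not yet been measured. It differs from compound 3 in one respect: 3-(trifluoromethyl)phenyl in place of 2-methylphenyl on a saturated chain carbon bound to an aromatic carbon. Going by the values given here, no measured pair shows this change on its own, so the direction and size of the step can only be expected, not read. Since compound 1, which carries its methyl at the 3-position of the benzylic ring, gives 140 nM, a modest gain in potency is expected for compound 4 rather than a loss, with the step from compound 3 to compound 4 estimated as a 2.7-fold lower number from compound 3 to compound 4 (0.43 log units; beyond the scatter). Compound 4 is therefore expected to give about 2000 nM in this assay, with a range from 400 nM to 10000 nM.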

Compound 4, half-maximal inhibitory concentration: 86 nM
For compound 4 the middle estimate is 23-fold (1.37 log units) above the measured one, and the stated range ends above it.
By their numbers in this assay, from the lowest: compounds 4 and 1 (each within the scatter of the next); then compound 3. At a limit, above all of these: compound 2.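

Going by these compounds alone, the single swap of 2-methylphenyl for 3-(trifluoromethyl)phenyl on a saturated chain carbon bound to an aromatic carbon is the only step between compounds differing in one place, and in this assay it gives a 63-fold lower number from compound 3 to compound 4 (1.80 log units; beyond the scatter). Within the data shown here, this shows that, with the rest of the structure held fixed, the aryl group at this position alone can move the number by a large margin, which the earlier compounds, all differing in more than one place, could not show. Nothing shown gives a reason for this step.

The swap changes both the substituent and where it sits on the phenyl ring, so the two contributions cannot be separated here. From the compounds shown here alone, whether an amine or a nitrile on this phenyl ring would give a similar number remains open.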